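Chloro for Bromo: A Small Halogen Swap

The compounds below may be only part of what the source reports. "The series", "measured", "known", "first", "only" and "open" are said of these compounds alone.

Two measured compounds share a common core. In an ADME assay on LLC-PK1 cells (Sus scrofa) for inhibition, read by MTT assay, with a stated time of 120 h (on this read-out lower numbers stand for stronger inhibition and higher numbers for weaker inhibition), compound 1 `Cc1cc2nc(CCC3CCCCC3)[nH]c2cc1C` gives 43900 nM. Compound 2 `Brc1ccc2[nH]c(CCC3CCCCC3)nc2c1` gives 32600 nM in this assay; the two numbers lie within the usual scatter of each other, so compound 2 cannot be set apart from compound 1 on this read-out. Compound 3 `Clc1ccc2[nH]c(CCC3CCCCC3)nc2c1` differs from compound 2 by chloro in place of bromo on an aromatic carbon. Going by the values given here, no measured pair shows such a swap, so its step size is unknown. The expected step from compound 2 to compound 3 is a 1.2-fold higher number from compound 2 to compound 3 (0.07 log units; within the scatter), nothing beyond the scatter. Compound 3 is estimated at 38000 nM, within a range from 15000 nM to 95000 nM.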

Compound 3, half-maximal inhibitory concentration: 17100 nM
Beside the measured number, compound 3's estimate is 2.2-fold (0.35 log units) above it; low and high end bracket the measured number.
By their numbers in this assay, from the lowest: compounds 3, 2 and 1 (each within the scatter of the next, the first and the last beyond it).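

In this assay, going by these compounds alone, the swap gives a 1.9-fold lower number from compound 2 to compound 3 (0.28 log units; within the scatter), which is the first measured size for this change. At this aromatic carbon, chloro and bromo therefore cannot be told apart on this read-out. No measurement shown bears on why the step has this size.

The compounds shown cover only two halogens at this place. From the compounds shown here alone, whether fluoro, an amine or a carboxylic acid on the same aromatic carbon would shift the number beyond the usual scatter remains open.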